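Stretching a Phenyl Arm on a Weak Receptor Agonist

The source may report more compounds than this note shows. Statements on the series, on what has been measured and on what is new or still open speak of the compounds shown alone.

Of the compounds shown here, three sharing the same acid-bearing core have been tested in an in vitro functional assay on cells for agonist activity at Bombesin receptor subtype-3 (Homo sapiens), read by luminescence and calcium flux; on this read-out lower numbers stand for an effect already at smaller amounts and higher numbers for an effect only at larger amounts of compound. Compound 1, with structure `O=C(O)c1ccccc1-c1ccc(CCc2ncc(-c3ccccc3)[nH]2)cc1`, gives 4950 nM in this assay. Compound 3, with structure `CCCCc1cnc(/C=C/c2ccc(-c3ccccc3C(=O)O)cc2)[nH]1`, gives 4380 nM; the two numbers lie within the scatter of each other, so neither can be called more or less active than the other. Compound 2, with structure `CCCCc1cnc(Cc2ccc(-c3ccccc3C(=O)O)cc2)[nH]1`, reaches only the assay limit of > 10000 nM, which is a boundary of the measurement rather than a number, as noted in the limit of > 10000 nM in this assay, at which 1 of the 3 values shown sits. Among the two actual numbers, compound 1 stands as the higher one, though only by a margin inside the scatter.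

Compound 4, with structure `O=C(O)c1ccccc1-c1ccc(CCc2ncc(CCc3ccccc3)[nH]2)cc1`, has not yet been measured. It differs from compound 1 in one place: phenethyl in place of phenyl on an aromatic carbon. Going by the values given here, no measured pair of compounds in this set shows what such a change does, so the size of the step can only be guessed. The expectation is a step from compound 1 to compound 4 of a 1.2-fold lower number from compound 1 to compound 4 (0.09 log units; within the scatter), which is no larger than the scatter itself. Compound 4 is therefore estimated at 4000 nM, with a range from 1000 nM to 15000 nM.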

Compound 4, half-maximal effective concentration: 1320 nM
Compound 4: middle estimate off by 3.0-fold (0.48 log units), on the high side; the measured number falls inside the stated range.
By their numbers in this assay, from the lowest: compound 4; then compounds 3 and 1 (each within the scatter of the next). At a limit, above all of these: compound 2.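

Going by these compounds alone, replacing phenyl with phenethyl on this aromatic carbon of the five-membered ring gives the first step in the set between two measured compounds that differ in one place, and in this assay it reads a 3.8-fold lower number from compound 1 to compound 4 (0.57 log units; beyond the scatter). The position therefore accepts a larger group without a loss in this read-out, and the lower number comes with a modest step rather than a large one. The entering and leaving groups carry the same six-membered aromatic ring of carbon only and have no hydrogen-bond donors or acceptors, so the listed difference is 8 heavy atoms against 6, but nothing measured here explains why the number falls.

One step cannot show whether the number depends on the length of the link to the ring, which a benzyl group or a longer phenylpropyl chain at this position would test. It also leaves open whether the terminal ring is needed at all, and whether an amine or an ether oxygen in the link would be tolerated as well as the carbon chain of phenethyl.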